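A few compounds are considered here, and "the series" means these few. Any claim that something is new, unique, unknown or untested is made for them only; others in the source may bear on it.

Measured compounds:
- compound 1, `CCCCCC(=O)c1ccc(CN(CCCCCCC(=O)O)S(C)(=O)=O)cc1`: 887 nM
- compound 2, `CC(C)(C)c1ccc(CN(Cc2cccc(CCC(=O)O)c2)S(C)(=O)=O)cc1`: 48 nM

Both compounds were tested in a functional assay on HEK293 cells for agonist activity at prostaglandin E2 receptor EP2 subtype (Rattus norvegicus), read by cAMP accumulation; a lower number here means that less compound is needed, a higher number that more compound is needed for the effect. Compound 1 has the higher of the two numbers; compound 2 sits at the lower value, a gap well beyond the usual scatter. The two differ in several places at once, so their pair shows only that two quite different designs around the shared sulfonamide core can land far apart in this assay.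

Compound 3, `CCCCCC(O)c1ccc(CN(CCCCCCC(=O)O)S(C)(=O)=O)cc1`, is the unmeasured compound, and it differs from compound 1 in one place: 1-hydroxyhexyl in place of pentylcarbonyl on an aromatic carbon. Within the data shown here, no measured pair mirrors this change, so the direction and size of its effect are open. The ketone of compound 1 is swapped for a carbinol carrying one hydrogen-bond donor, everything else kept. For compound 3 a moderate drop in the number is expected, the step of a 3.0-fold lower number from compound 1 to compound 3 (0.47 log units; beyond the scatter) being the estimate, somewhat beyond the scatter but far short of the distance to compound 2. The value expected for compound 3 is 300 nM, with a plausible range from 80 nM to 1500 nM.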

Compound 3, half-maximal effective concentration: 44 nM
For compound 3 the middle estimate is 6.8-fold (0.83 log units) above the measured one; the measured number lies below the stated range.
By their numbers in this assay, from the lowest: compounds 3 and 2 (each within the scatter of the next); then compound 1.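

At this position, on an aromatic carbon para to a large group, replacing pentylcarbonyl with 1-hydroxyhexyl in this assay gives a 20-fold lower number from compound 1 to compound 3 (1.30 log units; beyond the scatter), a large step that the earlier pair, differing in several places at once, could not isolate. The two groups have the same heavy atoms and neither contains a ring, but the carbonyl's double bond is lost and a hydrogen-bond donor appears, so a change this small in atom count can still move the number far beyond the scatter. No independent measurement bears on why this step is so large.

The compounds shown do not separate the gain of the hydroxyl hydrogen from the loss of the carbonyl double bond; a methoxy group or an amine on the same carbon would help tell these two changes apart. On these data alone, it also remains open whether a similar step would appear of compound 2, or how a shorter or longer alkyl chain on the carbinol carbon would affect the number.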